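The source may report more compounds than this note shows. Statements on the series, on what has been measured and on what is new or still open speak of the compounds shown alone.

Compound 1 `CCNC(=O)Nc1sc2ccccc2c1C(=O)N1CCN(C2CCN(C(C)=O)CC2)CC1`, compound 2 `CCNC(=O)Nc1sc2ccccc2c1C(=O)N1CCN(C2CCN(C(=O)C(C)(C)C)CC2)CC1` and compound 3 `CCNC(=O)Nc1sc2ccccc2c1C(=O)N1CCN(C2CCN(C(=O)OC3CCCC3)CC2)CC1` share one core and differ in the group on a carbonyl carbon. In a functional assay on HepG2 cells (Homo sapiens) for inhibition, read by scintillation counting, with a stated time of 2 h (on this read-out higher numbers stand for weaker inhibition and lower numbers for stronger inhibition), compound 1 gives "not determined" (no result reported) and so offers no comparison. In this assay, within the data shown here, compound 2 gives 450 nM and compound 3 gives 512 nM as the only other number. These two numbers lie within the scatter of each other, so compound 3 stands level with compound 2.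

Compound 4 `CCNC(=O)Nc1sc2ccccc2c1C(=O)N1CCN(C2CCN(C(=O)OC(C)(C)CF)CC2)CC1` is still unmeasured. It differs from compound 3 by one swap, 1-(fluoromethyl)-1-methylethyl in place of cyclopentyl on an oxygen next to a carbonyl group.

Among the measured compounds shown here, one measured step bears on this swap only indirectly: a 1.1-fold higher number from compound 2 to compound 3 (0.06 log units; within the scatter), with cyclopentyloxy in place of tert-butyl on a carbonyl carbon. For the measured compounds named here, no measured compound carries fluorine, so the evidence is thin. No step beyond the scatter is therefore expected in this assay, in either direction. The expected step is a 1.0-fold lower number from compound 3 to compound 4 (0.01 log units; within the scatter) as an estimate. For compound 4 the estimated value is 500 nM, with an expected range from 250 nM to 1000 nM as its ends.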

Compound 4, half-maximal inhibitory concentration: 61 nM
Beside the measured number, compound 4's estimate is 8.2-fold (0.91 log units) above it, and the stated range ends above it.
By their numbers in this assay, from the lowest: compound 4; then compounds 2 and 3 (each within the scatter of the next).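

Replacing cyclopentyl with 1-(fluoromethyl)-1-methylethyl on an oxygen next to a carbonyl group gives an 8.4-fold lower number from compound 3 to compound 4 (0.92 log units; beyond the scatter) in this assay, which shows that this position is sensitive to the group it carries. The comparison with the tert-butyl group on the carbonyl carbon points the same way, with a 7.4-fold lower number from compound 2 to compound 4 (0.87 log units; beyond the scatter) as the step, even though compound 2 and compound 3 stand level with each other. In the step from compound 3, the ring leaves and fluorine enters together, so this single change cannot separate the two.

Nothing measured here accounts for the gain in inhibition. On these data alone, it remains open whether a plain tert-butyl group on the same oxygen, without fluorine, or a group carrying a trifluoromethyl would match compound 4.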